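The source may hold more compounds than are shown below. What is called first, only, known or untested is meant among the compounds shown, and "the series" means these compounds.

Measured so far in a functional assay on RPMI 8402 cells (Homo sapiens) for cytotoxicity; on this read-out lower numbers stand for stronger inhibition and higher numbers for weaker inhibition:

Compound 1, `Cc1cccc(-c2nc3cc(-c4nc5cc(C#N)ccc5[nH]4)ccc3[nH]2)c1` — 860 nM
Compound 2, `Cc1ccc(-c2nc3cc(-c4nc5cc(C#N)ccc5[nH]4)ccc3[nH]2)cc1` — 570 nM
Compound 3, `Cc1cccc(-c2nc3cc(-c4nc5cc(N6CCN(C)CC6)ccc5[nH]4)ccc3[nH]2)c1` — 360 nM

Compound 1 and compound 2 share a core and differ by 4-methylphenyl in place of 3-methylphenyl on an aromatic carbon. That change gave a 1.5-fold lower number from compound 1 to compound 2 (0.18 log units; within the scatter). Compound 3 carries a different core; against compound 1 the difference is 4-methylpiperazin-1-yl in place of cyano on an aromatic carbon, a change that gave a 2.4-fold lower number from compound 1 to compound 3 (0.38 log units; beyond the scatter). Compound 3 has the lowest number of the three, but its gap to compound 2 lies within the scatter, so no order between those two is claimed.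

Compound 4, `Cc1ccc(-c2nc3cc(-c4nc5cc(N6CCN(C)CC6)ccc5[nH]4)ccc3[nH]2)cc1`, is not yet measured. It differs from compound 3 by 4-methylphenyl in place of 3-methylphenyl on an aromatic carbon, the same change as that from compound 1 to compound 2, made at the same place.

Expectation for compound 4 in this assay: the earlier instance of this change gave a small step that stayed within the scatter, so a step of similar size is expected, namely a 1.4-fold lower number from compound 3 to compound 4 (0.16 log units; within the scatter). This rests on one prior pair only, so the range is kept wide. Compound 4 is estimated at 250 nM, with a likely span from 120 nM to 550 nM.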

Compound 4, half-maximal inhibitory concentration: 830 nM
Beside the measured number, compound 4's estimate is 3.3-fold (0.52 log units) below it, and the stated range ends below it.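

With the 4-methylpiperazin-1-yl group present, 4-methylphenyl in place of 3-methylphenyl gives a 2.3-fold higher number from compound 3 to compound 4 (0.36 log units; beyond the scatter) in this assay, so the step seen on the core of compound 1 does not carry over to the core of compound 3: the same change on two cores in this assay, a 1.5-fold lower number (0.18 log units; within the scatter) from compound 1 to compound 2 and a 2.3-fold higher number (0.36 log units; beyond the scatter) from compound 3 to compound 4, 3.5-fold (0.54 log units) apart, beyond the scatter of two such steps. Read the other way, 4-methylpiperazin-1-yl in place of cyano gives a 1.5-fold higher number from compound 2 to compound 4 (0.16 log units; within the scatter) with 4-methylphenyl present, and this too differs from the step with 3-methylphenyl present: the same change on two cores in this assay, a 2.4-fold lower number (0.38 log units; beyond the scatter) from compound 1 to compound 3 and a 1.5-fold higher number (0.16 log units; within the scatter) from compound 2 to compound 4, 3.5-fold (0.54 log units) apart, beyond the scatter of two such steps. Across these four compounds the two changes therefore do not add independently, but this rests on a single set of pairs and gives neither a reason for the difference nor a rule for other cores.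

As far as these compounds go, it remains open whether an unsubstituted phenyl or a methoxyphenyl in place of the methylphenyl groups, or a carboxylic acid or a morpholine in place of cyano, would show the same dependence on the partner group. From the compounds shown here alone, how these compounds read in any other assay also remains open.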